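A few compounds are considered here, and "the series" means these few. Any claim that something is new, unique, unknown or untested is made for them only; others in the source may bear on it.

Of the compounds shown here, three sharing one core have been measured in an assay on cells for inhibition of interleukin-5 receptor subunit alpha (Mus musculus), read by WST assay, with a stated time of 48 h, in the presence of a further agent that is not named here; on this read-out lower numbers stand for stronger inhibition and higher numbers for weaker inhibition. Compound 1 `CCC(CO)NCc1nc2c(OCC3CCCCC3)cccc2[nH]1` gives 3500 nM. Compound 2 `OCC(NCc1nc2c(OCC3CCCCC3)cccc2[nH]1)c1ccccc1` gives 20000 nM. For compound 3 `c1ccc(CNCc2nc3c(OCC4CCCCC4)cccc3[nH]2)cc1` only a limit of the assay is known, > 30000 nM. Compound 3 therefore stands at the limit of > 30000 nM in this assay, at which 1 of the 3 values shown sits, and no measured number exists for it. The steps connecting these three compounds are a 5.7-fold higher number from compound 1 to compound 2 (0.76 log units; beyond the scatter), an at least 8.5-fold higher number from compound 1 to compound 3 (0.93 log units; beyond the scatter) and an at least 1.5-fold higher number from compound 2 to compound 3 (0.17 log units; that floor lies within the scatter).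

Compound 4 `COc1ccc(CNCc2nc3c(OCC4CCCCC4)cccc3[nH]2)cc1` has not yet been measured. It differs from compound 3 by methoxy in place of hydrogen on an aromatic carbon. Among the compounds with values here, none of the measured steps touches the aromatic ring itself: each exchanges the group on the amine nitrogen or the substituent on the chain carbon, and the two steps that lie beyond the scatter both run toward compound 3 rather than away from it. Within the data shown here, no measured step therefore bears directly on placing a methoxy on the ring. For this assay the expectation is no step beyond the scatter, so that compound 4 is expected to remain at or close to the limit. The estimated step is a step that the limit leaves unreadable from compound 3 to compound 4. Compound 4 is accordingly estimated at 40000 nM, with an expected range from 15000 nM to 100000 nM.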

Compound 4, half-maximal inhibitory concentration: > 30000 nM
Compound 4 was reported as a limit; the forecaster's own chance of this, stated with the estimate: 65%; the middle value does not contradict the limit.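

In this assay compound 4 gives > 30000 nM, which is a limit of the assay and not a number. Compound 3 and compound 4 both rest on limits, so the step between them cannot be read, and all that can be said is that methoxy on this aromatic carbon, para to a large group, did not bring a benzyl-type amine substituent to a measured value: the limit of > 30000 nM in this assay, at which 2 of the 4 values shown sit. Exchanging 1-(hydroxymethyl)propyl on the amine nitrogen for 4-methoxybenzyl gives an at least 8.5-fold higher number from compound 1 to compound 4 (0.93 log units; beyond the scatter), whereas exchanging 2-hydroxy-1-phenylethyl for 4-methoxybenzyl gives an at least 1.5-fold higher number from compound 2 to compound 4 (0.17 log units; that floor lies within the scatter), so only the first of these two exchanges is shown to lie beyond the scatter.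

As far as these compounds go, whether methoxy changes the read-out at all remains open, and that could be read only on a compound with a measured number, such as compound 2 with 4-methoxyphenyl in place of phenyl. Also open, from the compounds shown here alone, is how an amine or a carboxylic acid on the same aromatic carbon would read in this assay.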